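The source may hold more compounds than are shown below. What is called first, only, known or untested is meant among the compounds shown, and "the series" means these compounds.

Compound 1 `CCOC(=O)c1c(-c2cccc(-c3ccccc3)c2)[nH]c2cc(OC)ccc2c1=O`: > 22000 nM
Compound 2 `CCOC(=O)c1c(-c2cccc(-c3ccccc3)c2)[nH]c2cc(OC)c(OC)cc2c1=O`: > 22000 nM
Compound 3 `CCOC(=O)c1c(-c2cccc(-c3ccccc3)c2)[nH]c2cc(Cl)c(Cl)cc2c1=O`: > 22000 nM

In an ADME assay on HEK293 cells (Homo sapiens) for cytotoxicity, read by luminescence, with a stated time of 72 h (on this read-out lower numbers stand for an effect already at smaller amounts and higher numbers for an effect only at larger amounts of compound), all three entries are limits of the assay and not numbers. Compound 3 therefore has only a limit, > 22000 nM. The same holds across the series: the limit of > 22000 nM in this assay, at which 3 of the 3 values shown sit.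

Compound 4 `CCOC(=O)c1c(-c2cccc(-c3ccccc3)c2)[nH]c2cc(OC)c(Cl)cc2c1=O` has methoxy in place of chloro on an aromatic carbon, ortho to a chloro group (methoxy in place of chloro on an aromatic carbon). Among the measured compounds shown here, the one measured step that also adds a methoxy, a step that the two limits leave unreadable from compound 1 to compound 2, replaces hydrogen rather than chloro and gives no usable size. No clear shift in either direction is therefore expected, and the assay will probably report a limit again. The estimated step that the limit leaves unreadable from compound 3 to compound 4 is expected to stay within the usual scatter. For compound 4 the estimate is 25000 nM, with an expected range from 12000 nM to 50000 nM.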

Compound 4, half-maximal effective concentration: > 22000 nM
Compound 4 was reported as a limit; the forecaster's own chance of this, stated with the estimate: 85%; the middle value is on the limit's open side.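

Among the compounds shown here, compound 4 also gives only a limit, so no step among compound 1, compound 2, compound 3 and compound 4 can be read: the limit of > 22000 nM in this assay, at which 4 of the 4 values shown sit. The compounds shown leave open how large any of these changes would be in this assay, or in which direction it would go.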